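Methyl on the pyrrole nitrogen: compound 2 to compound 3

The compounds below may be only part of what the source reports. "The series", "measured", "known", "first", "only" and "open" are said of these compounds alone.

Measured compounds:
compound 1 `O=C(Nc1ccc(Oc2ccnc3[nH]ccc23)c(F)c1)c1cc2cccnc2n(-c2ccccc2)c1=O` 1260 nM
compound 2 `O=C(Nc1ccc(Oc2ccnc3[nH]ccc23)c(F)c1)c1cc2cccnc2n(-c2ccc(Br)cc2)c1=O` 1510 nM

In a functional assay on U-87MG ATCC cells for antiproliferative activity against U-87 MG (Homo sapiens), read by MTT assay, with a stated time of 72 h (on this read-out higher numbers stand for weaker inhibition and lower numbers for stronger inhibition), compound 2 gives the highest of the two numbers, yet its gap to compound 1 is within the scatter. Compound 3 `Cn1ccc2c(Oc3ccc(NC(=O)c4cc5cccnc5n(-c5ccc(Br)cc5)c4=O)cc3F)ccnc21` differs from compound 2 by methyl in place of hydrogen on an aromatic nitrogen. Going by the values given here, no measured step touches that nitrogen; the only step known, a 1.2-fold higher number from compound 1 to compound 2 (0.08 log units; within the scatter), concerns a different place and was within the scatter, so it offers no guide. The number for compound 3 is therefore estimated with low confidence, allowing a modest weakening a 2.3-fold higher number from compound 2 to compound 3 (0.37 log units; beyond the scatter), giving an expected 3500 nM (range 1000 nM to 15000 nM).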

Compound 3, half-maximal inhibitory concentration: 2580 nM
Compound 3: middle estimate off by 1.4-fold (0.13 log units), on the high side; the measured number falls inside the stated range.
By their numbers in this assay, from the lowest: compounds 1, 2 and 3 (each within the scatter of the next, the first and the last beyond it).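

In this assay methyl in place of hydrogen on the aromatic nitrogen of the five-membered ring gives a 1.7-fold higher number from compound 2 to compound 3 (0.23 log units; within the scatter) and so stays within the scatter. For this pair, the hydrogen on that nitrogen is therefore not needed to keep the number in the same range. Going by these compounds alone, this is the first reading at this position, and it concerns only the bromo-bearing compounds. As far as these compounds go, whether a longer chain such as ethyl, or a chain ending in an amine, would be accommodated on this nitrogen stays open. Nothing available explains the result.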